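Working notes: swapping the group on the carbonyl carbon

A few compounds are considered here, and "the series" means these few. Any claim that something is new, unique, unknown or untested is made for them only; others in the source may bear on it.

Measured so far in an in vitro ADME assay on microsomes (Homo sapiens) for metabolic stability; on this read-out higher numbers stand for a longer-lived compound and lower numbers for a shorter-lived compound
- compound 1 `Cc1c2c(n3c1CCCNC[C@H](C)Nc1cc-3ccc1C(N)=O)CC(C)(C)CC2=O` gives 0.167 h
- compound 2 `CC[C@H](N)C(=O)N1CCc2c(C)c3c(n2-c2ccc(C(N)=O)c(c2)N[C@@H](C)[C@H](C)C1)CC(C)(C)CC3=O` gives 0.417 h
- compound 3 `Cc1c2c(n3c1CCN(C(=O)C(C)(C)N)C[C@@H](C)[C@H](C)Nc1cc-3ccc1C(N)=O)CC(C)(C)CC2=O` gives 0.417 h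

Compound 3 stands level with compound 2, together the highest of the three numbers, and clearly over compound 1. Compound 4 `Cc1c2c(n3c1CCN(C(=O)[C@@H](O)C(C)C)C[C@@H](C)[C@H](C)Nc1cc-3ccc1C(N)=O)CC(C)(C)CC2=O` differs from compound 3 as follows: 1-hydroxy-2-methylpropyl in place of 1-amino-1-methylethyl on a carbonyl carbon. Within the data shown here, the one measured step at this place, no change at the digits printed from compound 2 to compound 3 (within the scatter), exchanged one amino-bearing group for another. Among the measured compounds shown here, no measured step replaces such a group with a hydroxy-bearing one, so the direction is open. In this assay the expected outcome is a 1.0-fold lower number from compound 3 to compound 4 (0.02 log units; within the scatter), with no shift estimated beyond the scatter. Compound 4 is expected at 0.4 h, with an estimated range of 0.17 h to 0.9 h for the measurement.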

Compound 4, half-life: 0.05 h
Compound 4: middle estimate off by 8.0-fold (0.90 log units), on the high side; the whole stated range lies above it.
By their numbers in this assay, from the lowest: compound 4; then compound 1; then compounds 2 and 3 (each within the scatter of the next).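

In this assay the group on this carbonyl carbon matters after all: 1-hydroxy-2-methylpropyl in place of 1-amino-1-methylethyl gives an 8.3-fold lower number from compound 3 to compound 4 (0.92 log units; beyond the scatter) and in place of 1-aminopropyl gives an 8.3-fold lower number from compound 2 to compound 4 (0.92 log units; beyond the scatter) while the exchange of one amino-bearing group for the other gives no change at the digits printed from compound 2 to compound 3 (within the scatter) on the same read-out. Among these compounds, then, both amino-bearing groups stand apart from the hydroxy-bearing one. No data at hand account for the drop.

Still open, from the compounds shown here alone, is whether the change of amino for hydroxy alone carries this step, or the different carbon branching also contributes. A 1-amino-2-methylpropyl group or a 1-hydroxy-1-methylethyl group on the same carbonyl carbon would separate the two.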